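This account rests on a few compounds, and the source may have more. Where it says the series, first, only, none or still open, it means among the compounds named here.

Three compounds share one core. Going by the values given here, compound 1 `Cc1nn(C)c(Oc2ccc(Br)cc2)c1/C=N\CCCCCOc1cc2oc(=O)cc(C)c2cc1Cl` gives 15300 nM in a functional assay on U-87MG ATCC cells for antiproliferative activity against U-87 MG (Homo sapiens), read by MTT assay, with a stated time of 72 h (on this read-out higher numbers stand for weaker inhibition and lower numbers for stronger inhibition), and compound 2 `Cc1ccc(Oc2c(/C=N\CCCCCOc3cc4oc(=O)cc(C)c4cc3Cl)c(C)nn2C)cc1` gives 7970 nM in this assay, the only single-point step being a 1.9-fold lower number from compound 1 to compound 2 (0.28 log units; within the scatter). Compound 3 `Cc1nn(C)c(Oc2cccc(Cl)c2)c1/C=N\CCCCCCOc1cc2oc(=O)cc(C)c2cc1Cl` gives 8460 nM in this assay; its number sits among the other two, each of them within the usual scatter of it. Compound 4 `Cc1nn(C)c(Oc2ccc(OC(F)(F)F)cc2)c1/C=N\CCCCCCOc1cc2oc(=O)cc(C)c2cc1Cl` differs from compound 3 by 4-(trifluoromethoxy)phenyl in place of 3-chlorophenyl on an oxygen on an aromatic ring. Among the compounds with values here, the one measured step on that part of the molecule, a 1.9-fold lower number from compound 1 to compound 2 (0.28 log units; within the scatter), stayed within the scatter, and no measured pair speaks to a 4-(trifluoromethoxy)phenyl group, so compound 4 is expected to show a step of a 1.0-fold higher number from compound 3 to compound 4 (0.00 log units; within the scatter) that does not clear the scatter. Compound 4 is estimated at 8500 nM, with a range from 3500 nM to 21000 nM.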

Compound 4, half-maximal inhibitory concentration: 9620 nM
Compound 4: the middle estimate sits 1.1-fold (0.05 log units) below what was measured, and the stated range covers the measured number.
By their numbers in this assay, from the lowest: compounds 2, 3, 4 and 1 (each within the scatter of the next).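

In this assay, 4-(trifluoromethoxy)phenyl in place of 3-chlorophenyl on the oxygen gives a 1.1-fold higher number from compound 3 to compound 4 (0.06 log units; within the scatter), so this position tolerates the change with no measurable shift. The entering group carries more heavy atoms and one hydrogen-bond acceptor, yet this second change on the ring, like the first, stays within the scatter. No evidence at hand explains this result. As far as these compounds go, whether an amine or a carboxylic acid on this ring would move the number beyond the scatter remains open, as does the effect of a longer chain.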